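The source may hold more compounds than are shown below. What is called first, only, known or untested is meant among the compounds shown, and "the series" means these compounds.

Measured compounds:
compound 1 `OCC(CO)OCn1c(SCc2ccccc2)nc2cc(Cl)c(Cl)cc21` — > 100000 nM
compound 2 `OCC(CO)OCn1cnc2cc(Cl)c(Cl)cc21` — > 100000 nM
compound 3 `OCC(CO)OCn1c(SCc2ccccc2)nc2c(Cl)c(Cl)ccc21` — 60000 nM

The read-out throughout is a functional assay on KB cells (Homo sapiens) for inhibition; on this read-out higher numbers stand for weaker inhibition and lower numbers for stronger inhibition. Compound 1 gives > 100000 nM, which is a limit of the assay and not a number. Compound 2 likewise gives > 100000 nM, again a limit. Among the compounds with values here, compound 3 is the only member with a number, at 60000 nM in this assay.

Within the data shown here, the one measured step, from compound 1 to compound 2, is a step that the two limits leave unreadable from compound 1 to compound 2; the change is hydrogen in place of benzylsulfanyl on an aromatic carbon. Both ends sit at a limit, so the size of this step cannot be read. Compound 3 shares its atoms with compound 1 but joins them differently; the difference between the two cores is not broken down here.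

Compound 4 `OCC(CO)OCn1cnc2c(Cl)c(Cl)ccc21` is not yet measured. It differs from compound 3 by hydrogen in place of benzylsulfanyl on an aromatic carbon, the same change as that from compound 1 to compound 2, with the place described in identical words. Since compound 3 starts from a measured number rather than a limit, the outcome is readable this time. Given (the limit of > 100000 nM in this assay, at which 2 of the 3 values shown sit), at which the benzylsulfanyl-free compound 2 sits, the step from compound 3 to compound 4 is expected at a 2.5-fold higher number from compound 3 to compound 4 (0.40 log units; beyond the scatter). Compound 4 is therefore estimated at 150000 nM, with a likely span from 50000 nM to 450000 nM, and a fair chance that this assay returns only a limit.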

Compound 4, half-maximal inhibitory concentration: > 100000 nM
Compound 4: no number, only a limit; the forecaster's own chance of this, stated with the estimate: 70%; the middle value does not contradict the limit.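

Compound 4 gives > 100000 nM in this assay, which is a limit of the assay and not a number. On the core of compound 3, hydrogen in place of benzylsulfanyl gives an at least 1.6-fold higher number from compound 3 to compound 4 (0.22 log units; that floor lies within the scatter), so the change is compatible with weaker inhibition on this core but does not establish it, and the true size of the step could be larger than this floor. The same change on the core of compound 1 cannot be read, with a limit at both ends of the step, so the two cores offer no comparison of size and the series does not show that the change carries over from one core to the other with the same effect.

Still open, as far as these compounds go, is whether an amine or a carboxylic acid in place of benzylsulfanyl, on the aromatic carbon between two ring nitrogen atoms, would give a number on either core. Also open is how large either benzylsulfanyl step really is, and the read-out offers little to settle this, with only compound 3 giving a number: the limit of > 100000 nM in this assay, at which 3 of the 4 values shown sit.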